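Swapping Methoxy for Amino on a Carbonyl Carbon

The source may report more compounds than this note shows. Statements on the series, on what has been measured and on what is new or still open speak of the compounds shown alone.

Of the compounds shown here, two built on the same core have been tested so far. In an ADME assay on CEM-SS cells (Homo sapiens) for cytotoxicity, read by XTT assay, with a stated time of 6 days (on this read-out higher numbers stand for lower toxicity in this test and lower numbers for higher toxicity in this test), compound 1 `CCCC(=O)OCSc1ccccc1C(=O)N[C@@H]1CCC[C@H]1C(N)=O` gives 43.7 uM as a measured number. Compound 2 `CCCC(=O)OCSc1ccccc1C(=O)NCC(=O)NCC(=O)OC` reads > 100 uM, which is a limit of the assay and not a number. On these data alone, its exact place on the scale therefore remains unknown.

Compound 3 `CCCC(=O)OCSc1ccccc1C(=O)NCC(=O)NCC(N)=O` differs from compound 2 in one place: amino in place of methoxy on a carbonyl carbon. This puts amino in place of methoxy on a carbonyl carbon, so methoxycarbonyl becomes carbamoyl. Among the compounds with values here, no measured pair here shows what this swap does, so the expectation for this assay starts from compound 2 alone, with its limit of > 100 uM as the anchor. No shift beyond the usual scatter is expected, and compound 3 may well be reported only as a limit too. The expected change a step that the limit leaves unreadable from compound 2 to compound 3 is small, within the scatter of repeat measurements. As a number, compound 3 is estimated at 110 uM, with an expected range from 60 uM to 200 uM.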

Compound 3, half-maximal toxic concentration: > 100 uM
Compound 3 gave a limit, no number (the forecaster's own chance of this, stated with the estimate: 70%); the middle value does not contradict the limit.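

In this assay compound 3 reads > 100 uM, which is a limit of the assay and not a number, so the carbamoyl end of the chain gives no sign of a toxic effect within the range the test can report. The size of the swap from methoxy to amino on this carbonyl carbon cannot be read, because compound 2 and compound 3 both stop at the same limit: the limit of > 100 uM in this assay, at which 2 of the 3 values shown sit.

The new information comes from the other side of the chain: putting ((carbamoylmethyl)carbamoyl)methyl in place of 2-carbamoylcyclopentyl on an amide-type nitrogen gives an at least 2.2-fold higher number from compound 1 to compound 3 (0.35 log units; beyond the scatter), which on this read-out means lower toxicity in this test.

On these data alone, how far compound 2 and compound 3 lie past the limit stays open, and so does whether the swap has any effect at all on toxicity in this test. As far as these compounds go, it is also open whether a hydroxy group or a methylamino group on the same carbonyl carbon would stay at this limit or give a measured number.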